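Removing one methyl from compound 2

A few compounds are considered here, and "the series" means these few. Any claim that something is new, unique, unknown or untested is made for them only; others in the source may bear on it.

Values measured so far in a physicochemical assay for lipophilicity, at pH 7.4 (a higher number here means a more lipophilic compound, a lower number a more polar compound), follow.
Compound 1 `CC(C)Oc1ccc(-c2nnc(-n3cc4c(n3)CCN(CCC(=O)O)C4)s2)cc1Cl` gives 3.26
Compound 2 `Cc1c2c(nn1-c1nnc(-c3ccc(OC(C)C)c(C#N)c3)s1)CCN(CCC(=O)O)C2` gives 2.76
Compound 3 `CC(C)Oc1ccc(-c2nnc(-n3ncc4c3CCN(CCC(=O)O)C4)s2)cc1Cl` gives 3.54

Compound 2 has the lowest number of the three. Compound 1 at 3.26 and compound 3 at 3.54 both stand above it by more than the usual scatter of such measurements.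

The next compound, compound 4 `CC(C)Oc1ccc(-c2nnc(-n3cc4c(n3)CCN(CCC(=O)O)C4)s2)cc1C#N`, has not been measured yet. It is reached from compound 2 by a single change, hydrogen in place of methyl on an aromatic carbon. Among the compounds with values here, no measured pair here shows this change alone, so there is no direct precedent for its size. A small downward step in this assay is expected, one that may only just clear the scatter. The estimated change is a number 0.31 log units lower from compound 2 to compound 4 (beyond the scatter) and it remains uncertain. For compound 4 the estimate is 2.45 within an expected range of 2.1 to 2.8 on this scale.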

Compound 4, distribution coefficient: 2.58
For compound 4 the middle estimate is 0.13 log units below the measured one; the measured number falls inside the stated range.
By their numbers in this assay, from the lowest: compounds 4 and 2 (each within the scatter of the next); then compounds 1 and 3 (each within the scatter of the next).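

In this assay, hydrogen in place of methyl on this aromatic carbon, next to the ring nitrogen, gives a number 0.18 log units lower from compound 2 to compound 4 (within the scatter) and so leaves no readable difference between the two groups at this position. Cyano in place of chloro on an aromatic carbon gives a number 0.68 log units lower from compound 1 to compound 4 (beyond the scatter) and shows that, of these two single changes, only this one moves the number beyond the scatter. Nothing at hand explains either step.

Going by these compounds, the methyl change is seen here only in compounds carrying the cyano group, so its size alongside the chloro group stays open. Also open, on these data alone, is whether an amine or a longer chain on this aromatic carbon would give a step beyond the scatter, since only hydrogen and methyl are compared there.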